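The compounds below may be only part of what the source reports. "The series", "measured", "known", "first", "only" and "open" are said of these compounds alone.

Measured so far:
compound 1 `CC(C)c1sc(-c2ccccc2)c(-c2cccc(F)c2)c1/C=C/[C@@H](O)C[C@@H](O)CC(=O)O`; in an assay on microsomes for inhibition of 3-hydroxy-3-methylglutaryl-coenzyme A reductase (Rattus norvegicus) (on this read-out higher numbers stand for weaker inhibition and lower numbers for stronger inhibition), compound 1 gives 49 nM
compound 2 `CC(C)=Cc1sc(C(C)C)c(/C=C/[C@@H](O)C[C@@H](O)CC(=O)O)c1-c1ccc(F)cc1`; in this assay compound 2 gives 15 nM

Compound 2 holds the lowest of the two numbers. The only other point, compound 1, stands at a higher number, and that gap lies beyond the scatter. Within the data shown here, the two structures differ in more than one place, so no single step is counted between them; their values show only that compound 2 is the stronger inhibitor of the pair.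

Compound 3 `CC(C)c1sc(CO)c(-c2ccc(F)cc2)c1/C=C/[C@@H](O)C[C@@H](O)CC(=O)O` has not yet been measured. It differs from compound 2 in a single place: hydroxymethyl in place of 2-methylprop-1-en-1-yl on an aromatic carbon. Among the measured compounds shown here, no measured pair isolates this change, so the expectation rests on compound 2 alone and on the general size of such exchanges. The exchange is expected to move this assay toward a higher number, by a modest amount that may or may not exceed the scatter. The step of a 2.7-fold higher number from compound 2 to compound 3 (0.43 log units; beyond the scatter) is the expected size of this move. Compound 3 is therefore estimated at 40 nM, within an expected range of 12 nM to 150 nM.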

Compound 3, half-maximal inhibitory concentration: 325 nM
The estimate for compound 3 lay 8.1-fold (0.91 log units) below the measured number, and the stated range ends below it.
By their numbers in this assay, from the lowest: compound 2; then compound 1; then compound 3.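

In this assay, hydroxymethyl in place of 2-methylprop-1-en-1-yl on the aromatic carbon next to the ring sulfur gives a 22-fold higher number from compound 2 to compound 3 (1.34 log units; beyond the scatter), a large step and the only single-place comparison among the compounds shown, so the group at this position clearly matters for this read-out. The exchange replaces 4 heavy atoms, all carbon, with a double bond outside aromatic rings and no hydrogen-bond donor or acceptor, by 2 heavy atoms with 1 hydrogen-bond donor and 1 hydrogen-bond acceptor, so size, the double bond and the donor and acceptor count all change in this one step. No measurement at hand accounts for the size of the step.

Still open, on these data alone, is whether a saturated 2-methylpropyl group, with the same carbon count and no double bond, would stay close to compound 2, and whether a methoxymethyl group, which keeps the oxygen but has no hydroxyl hydrogen, would stay close to compound 3. Also open, as far as these compounds go, is whether the exchange moves the number as far when the ring atom next to it bears something other than 4-fluorophenyl.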